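Trimming a Cyclopropylmethyl to Methyl on a Silent Scaffold

A few compounds are considered here, and "the series" means these few. Any claim that something is new, unique, unknown or untested is made for them only; others in the source may bear on it.

Compound 1 `c1cnc2c(c1)CCC[C@@H]2N(CC1CC1)C[C@H]1Cc2c(cccc2N2CCNCC2)CN1` was tested in a functional assay on CCRF-CEM cells for agonist activity at C-X-C chemokine receptor type 4 (Homo sapiens), read by calcium flux, with a stated time of 25 min (a higher number here means that more compound is needed for the effect, a lower number that less compound is needed), and there compound 1 gives > 30000 nM, which is a limit of the assay rather than a measured number. Its two companions share that outcome. Compound 2 `CN(C[C@@H]1Cc2c(cccc2N2CCNCC2)CN1)[C@H]1CCCc2cccnc21` gives > 30000 nM in this assay, again a limit. Compound 3 `CN(C[C@H]1Cc2c(cccc2N2C[C@@H]3C[C@H]2CN3)CN1)[C@H]1CCCc2cccnc21` gives > 30000 nM in this assay, also a limit. The picture is therefore uniform: the limit of > 30000 nM in this assay, at which 3 of the 3 values shown sit, and compound 1 stands nowhere in particular among them, since none of the three returned a number.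

Compound 4 `CN(C[C@H]1Cc2c(cccc2N2CCNCC2)CN1)[C@H]1CCCc2cccnc21` is the untested member. It differs from compound 1 by hydrogen in place of cyclopropyl on a saturated chain carbon bound to an amine nitrogen, which at one bond further out reads cyclopropylmethyl to methyl. Within the data shown here, no measured pair here shows what that change does, so its direction cannot be read from the data.

Given that every measured compound sat at the limit, the step from compound 1 to compound 4 is expected to be none beyond the scatter, which is what a step that the limit leaves unreadable from compound 1 to compound 4 expresses. For compound 4 the estimate in this assay is 40000 nM, with an expected range from 15000 nM to 150000 nM, and most likely the assay will again report only a limit.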

Compound 4, half-maximal effective concentration: > 30000 nM
Compound 4: only a limit was reported; the forecaster's own chance of this, stated with the estimate: 85%; the middle value does not contradict the limit.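

Compound 4 also returned only a limit in this assay, so no step from compound 1, compound 2 or compound 3 to compound 4 can be read, and the picture stays uniform: the limit of > 30000 nM in this assay, at which 4 of the 4 values shown sit.

The compounds shown leave open whether the change from cyclopropylmethyl to methyl, the ring group exchanged between compound 3 and compound 4, or the difference in configuration between compound 2 and compound 4 has any effect in this assay.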